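The compounds below may be only part of what the source reports. "The series", "measured", "known", "first", "only" and "open" are said of these compounds alone.

Compound 1 `O=C(O[C@H]1C[C@H](n2cc(F)c(=O)[nH]c2=O)O[C@@H]1COP(=O)(O)Oc1cccnc1)c1ccccc1` and compound 2 `O=c1[nH]c(=O)n([C@H]2C[C@H](O)[C@@H](COP(=O)(O)Oc3ccccc3)O2)cc1F` share the same core but differ from each other at more than one place, so their numbers stand side by side without a single-change step between them. In a functional assay on Caco-2 cells (Homo sapiens) for cytotoxicity, read by MTT assay, with a stated time of 48 h (a higher number here means a weaker inhibitor, a lower number a stronger inhibitor), compound 1 gives 2500 nM. In this assay compound 2 gives 26600 nM, the highest of the two numbers; the nearest number, that of compound 1, lies beyond the scatter below it.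

Compound 3 `O=c1[nH]c(=O)n([C@H]2C[C@H](O)[C@@H](COP(=O)(O)Oc3cccnc3)O2)cc1F` is compound 2 with one change: pyridin-3-yl in place of phenyl on an oxygen. Among the compounds with values here, no measured pair isolates this change. Compound 1 carries the same pyridin-3-yl group on the oxygen, yet it also differs from compound 2 at another place, so its value is only a loose pointer. The step from compound 2 to compound 3 is expected to be small, toward a lower number at most, and likely within the scatter, about a 1.8-fold lower number from compound 2 to compound 3 (0.25 log units; within the scatter). Compound 3 is expected to give 15000 nM in this assay, with a range from 5000 nM to 40000 nM.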

Compound 3, half-maximal inhibitory concentration: 3390 nM
For compound 3 the middle estimate is 4.4-fold (0.65 log units) above the measured one; the measured number lies below the stated range.
By their numbers in this assay, from the lowest: compounds 1 and 3 (each within the scatter of the next); then compound 2.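

In this assay the aryl group on the oxygen whose other neighbour is phosphorus is not a silent place: pyridin-3-yl in place of phenyl gives a 7.8-fold lower number from compound 2 to compound 3 (0.89 log units; beyond the scatter) and is now read as a single change. Hydrogen in place of benzoyl on an oxygen on a saturated carbon gives a 1.4-fold higher number from compound 1 to compound 3 (0.13 log units; within the scatter), so with pyridin-3-yl present, the benzoyl group makes no difference that can be told from the scatter. Nothing at hand bears on the origin of either step.

Still open, on these data alone, is whether benzoyl on that saturated-carbon oxygen would read the same with phenyl on the other oxygen. Also open, as far as these compounds go, is how pyridin-2-yl, pyridin-4-yl, or a pyridin-3-yl ring carrying an amine or a carboxylic acid would compare with pyridin-3-yl itself.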